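Compound 4: a methoxy added to the core of compound 3

The source may report more compounds than this note shows. Statements on the series, on what has been measured and on what is new or still open speak of the compounds shown alone.

Three measured compounds share one core and differ only in the group on the aromatic ring of the amide side. Compound 1 `CCc1ccccc1NC(=O)CCN1CCC(Cc2ccccc2)CC1` carries an ethyl there and gives 0.17 ug/mL in an assay on ileum with histamine H1 receptor (Cavia porcellus) as the target; a lower number here means a stronger inhibitor, a higher number a weaker inhibitor. Compound 2 `O=C(CCN1CCC(Cc2ccccc2)CC1)Nc1ccccc1F` carries a fluoro and gives 0.28 ug/mL in this assay. Compound 3 `O=C(CCN1CCC(Cc2ccccc2)CC1)Nc1ccccc1` carries a hydrogen and gives 0.49 ug/mL in this assay; its number lies beyond the scatter from compound 1 and within the scatter from compound 2.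

Compound 4 `COc1ccccc1NC(=O)CCN1CCC(Cc2ccccc2)CC1` is not yet measured. The change from compound 3 is methoxy in place of hydrogen on an aromatic carbon. Among the measured compounds shown here, two measured steps bear on it: a 2.9-fold higher number from compound 1 to compound 3 (0.46 log units; beyond the scatter) and a 1.8-fold higher number from compound 2 to compound 3 (0.24 log units; within the scatter). Both go the same way, so replacing the hydrogen with a group is expected to lower the number in this assay, modestly, with the size uncertain because the ethyl of compound 1 and the fluoro of compound 2 differ from a methoxy. Compound 4 is therefore estimated at 0.25 ug/mL, with a range from 0.12 ug/mL to 0.55 ug/mL. The step this estimate implies is a 2.0-fold lower number from compound 3 to compound 4 (0.29 log units; within the scatter).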

Compound 4, half-maximal inhibitory concentration: 0.34 ug/mL
Estimate against measurement, compound 4: 1.4-fold (0.13 log units) below, and the stated range covers the measured number.
By their numbers in this assay, from the lowest: compounds 1, 2, 4 and 3 (each within the scatter of the next, the first and the last beyond it).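

In this assay, methoxy on an aromatic carbon, ortho to a large group, gives a 1.4-fold lower number from compound 3 to compound 4 (0.16 log units; within the scatter) and so cannot be told apart from hydrogen at this position. Among the compounds shown here, the comparisons with the other two groups are equally unresolved: a 1.2-fold higher number from compound 2 to compound 4 (0.08 log units; within the scatter) and a 2.0-fold higher number from compound 1 to compound 4 (0.30 log units; within the scatter) place methoxy within the scatter of both fluoro and ethyl, leaving ethyl as the only group with a step from hydrogen beyond the scatter, seen in a 2.9-fold higher number from compound 1 to compound 3 (0.46 log units; beyond the scatter) and not matched by fluoro or methoxy. No measurement offers an explanation for these steps.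

The compounds shown leave open whether a longer chain, an amine or a carboxylic acid at this position would move the number beyond the scatter from compound 3. They also leave open whether these steps would hold on a different core, as all four compounds share one.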